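This account rests on a few compounds, and the source may have more. Where it says the series, first, only, none or still open, it means among the compounds named here.

The measured compounds:
compound 1, `COc1nc(N)nc2c1c(-c1ccccc1)cn2[C@@H]1O[C@H](CO)[C@@H](O)[C@H]1O`, > 20000 nM
compound 2, `COc1ncnc2c1c(-c1ccccc1)cn2[C@@H]1O[C@H](CO)[C@@H](O)[C@H]1O`, > 20000 nM
compound 3, `O=c1[nH]cnc2c1c(-c1cc3ccccc3o1)cn2[C@@H]1O[C@H](CO)[C@@H](O)[C@H]1O`, > 20000 nM

In a functional assay on A549 cells (Homo sapiens), read by MTT assay, with a stated time of 72 h (on this read-out higher numbers stand for weaker inhibition and lower numbers for stronger inhibition), compound 1 gives only a limit of the assay, > 20000 nM. Compound 2 likewise stops at a limit, > 20000 nM. Compound 3 also sits at a limit, > 20000 nM. Compound 1 differs from compound 2 by amino in place of hydrogen on an aromatic carbon, and the step that the two limits leave unreadable from compound 2 to compound 1 cannot be sized since (the limit of > 20000 nM in this assay, at which 3 of the 3 values shown sit).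

Compound 4, `Nc1nc2c(c(-c3cc4ccccc4o3)cn2[C@@H]2O[C@H](CO)[C@@H](O)[C@H]2O)c(=O)[nH]1`, is not yet measured and differs from compound 3 by amino in place of hydrogen on an aromatic carbon. This is the same kind of change as from compound 2 to compound 1, though the surroundings differ: in compound 1 the carbon is meta to a methoxy group (2 heavy atoms), in compound 4 it is meta to a group of 1 heavy atom. The difference between the cores of compound 2 and compound 3 is not broken down here. In this assay the step from compound 3 to compound 4 is expected to be a step that the limit leaves unreadable from compound 3 to compound 4, resting on the unreadable step that the two limits leave unreadable from compound 2 to compound 1 and on compound 3 sitting at a limit. Compound 4 is therefore estimated at 30000 nM, with a range from 8000 nM to 100000 nM, most likely reported again only as a limit.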

Compound 4, half-maximal inhibitory concentration: > 100000 nM
Compound 4 ended at the assay's limit; the forecaster's own chance of this, stated with the estimate: 85%; middle value at least 3.3-fold (0.52 log units) from the limit.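

Compound 3 and compound 4 both stop at limits in this assay, and the step between them cannot be read. The compounds shown leave open whether amino in place of hydrogen on an aromatic carbon changes inhibition at all.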